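A few compounds are considered here, and "the series" means these few. Any claim that something is new, unique, unknown or untested is made for them only; others in the source may bear on it.

Three compounds built on a shared core were measured in an assay on CHO cells for displacement of a labelled ligand from adenosine receptor A3 (Homo sapiens), read by scintillation counting, with a stated time of 45 min, tested at 1 uM, in the presence of a further agent that is not named here; a higher number here means more inhibition at the concentration tested (going by the name of the read-out), a lower number less inhibition. Compound 1 `CCCn1c(=O)[nH]c2nc(-c3ccc(S(=O)(=O)N4CCN(c5cccc(Br)c5)CC4)cc3)[nH]c2c1=O` gives 27%, compound 2 `CCCn1c(=O)[nH]c2nc(-c3ccc(S(=O)(=O)N4CCN(c5cccc(F)c5)CC4)cc3)[nH]c2c1=O` gives 44%, and compound 3 `CCCn1c(=O)[nH]c2nc(-c3ccc(S(=O)(=O)N4CCN(c5ccc(Br)cc5)CC4)cc3)[nH]c2c1=O` gives 29%. On these numbers compound 3 stands second highest of the three: its nearest neighbour is compound 1, a number 2 percentage points higher from compound 1 to compound 3 (within the scatter), while compound 2 lies furthest from it, a number 15 percentage points lower from compound 2 to compound 3 (beyond the scatter).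

The next compound, compound 4 `CCCn1c(=O)[nH]c2nc(-c3ccc(S(=O)(=O)N4CCN(c5ccccc5)CC4)cc3)[nH]c2c1=O`, differs from compound 3 by hydrogen in place of bromo on an aromatic carbon. Going by the values given here, two measured steps bear on this change. The move from one bromo position to another, a number 2 percentage points higher from compound 1 to compound 3 (within the scatter), shows that shifting the bromine around the ring made no difference beyond the scatter. The exchange of bromo for fluoro, a number 17 percentage points higher from compound 1 to compound 2 (beyond the scatter), was a modest rise, and the same pairing seen from the other side, a number 15 percentage points lower from compound 2 to compound 3 (beyond the scatter), was a modest fall. Among the compounds with values here, removing the halogen altogether goes in the direction of the smaller substituent, so a modest rise is expected in this assay , though with only one comparable step the size is uncertain.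

Compound 4 is therefore expected to give 38%, within a range from 22% to 55%. The step that this estimate implies, a number 9 percentage points higher from compound 3 to compound 4 (within the scatter), is expected to be modest because a number 17 percentage points higher from compound 1 to compound 2 (beyond the scatter) was itself modest.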

Compound 4, a percentage reported as inhibition, at one concentration (the size of the read-out at that concentration, not a potency): 27%
For compound 4 the middle estimate is 11 percentage points above the measured one; low and high end bracket the measured number.
By their numbers in this assay, from the lowest: compounds 1, 4 and 3 (each within the scatter of the next); then compound 2.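

Taking the halogen off this ring does not separate the plain phenyl compound from either bromo compound in this assay: the loss of the bromine para to a large group gives a number 2 percentage points lower from compound 3 to compound 4 (within the scatter), and the other bromo compound gives no change at the digits printed from compound 1 to compound 4 (within the scatter). Among these four compounds, only the fluoro compound stands apart, with a number 17 percentage points lower from compound 2 to compound 4 (beyond the scatter), so the hydrogen compound now gives a reference that the earlier compounds lacked: bromo at either of the two ring positions shown reads the same as no substituent, while fluoro does not. Nothing available here accounts for this difference between fluoro and bromo.

Going by these compounds alone, with only one fluoro compound, it remains open whether the reading of compound 2 belongs to fluoro itself or to fluoro at that particular ring position, and a fluoro group on the carbon para to a large group would bear directly on this. From the compounds shown here alone, it is also open how this ring responds to groups other than halogens, such as a methoxy group, an amine, a nitrile or a carboxylic acid.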